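Extending the chain on the ring nitrogen of compound 2

The source may report more compounds than this note shows. Statements on the series, on what has been measured and on what is new or still open speak of the compounds shown alone.

Measured so far:
- compound 1, `COc1ccc(-c2cc3c(OC)ccc(OC)c3nc2O)cc1`, in a functional assay on LoVo cells (Homo sapiens) for cytotoxicity, read by colorimetric assay and MTT assay (on this read-out lower numbers stand for stronger inhibition and higher numbers for weaker inhibition), compound 1 gives 10000 nM
- compound 2, `COc1ccc(-c2cc3c(OC)cc(OC)cc3n(C)c2=O)cc1`, in this assay compound 2 gives 10000 nM

Compound 1 and compound 2 share a core carrying methoxy groups and the same methoxyphenyl substituent. Compound 2 stands level with compound 1 at the digits shown, and the two values lie within the scatter of each other, so nothing can be said of order between them. Both sit at the weak end of the scale in this assay.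

Compound 3, `COc1ccc(-c2cc3c(OC)cc(OC)cc3n(CCCC#N)c2=O)cc1`, has not yet been tested. It differs from compound 2 in one place: 2-cyanoethyl in place of hydrogen on a saturated chain carbon bound to an aromatic nitrogen. The chain that is attached to the ring nitrogen of compound 2 is thus lengthened, and a nitrile is added at its end.

Among the measured compounds shown here, there is no measured pair here that shows what such a chain does. Since compound 2 gives 10000 nM and compound 1 gives 10000 nM, both weak, the expectation is for compound 3 to stay near that level, with a step of no change at the digits printed from compound 2 to compound 3 (within the scatter) that is not beyond the scatter. Compound 3 is expected to give about 10000 nM, within a range from 4000 nM to 30000 nM.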

Compound 3, half-maximal inhibitory concentration: 10000 nM
The estimate for compound 3 equals the measured number at the digits printed; the measured number falls inside the stated range.
By their numbers in this assay, from the lowest: compounds 1, 2 and 3 (each within the scatter of the next).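

Among the compounds shown here, replacing methyl with 3-cyanopropyl on the ring nitrogen gives the first measured pair for this position, and in this assay it shows no change at the digits printed from compound 2 to compound 3 (within the scatter). A longer chain ending in a nitrile can therefore stand at this position without moving the reading at the digits printed, and compound 3 stays at the weak end of the scale with 10000 nM. No measurement shown here offers an explanation for this result.

This is a single change on a compound that already reads weak, so it shows only that this one chain leaves the value where it was, not that the position is insensitive to every group. Going by these compounds, whether an amine, a carboxylic acid or a much longer chain on the ring nitrogen would give a different number in this assay remains open, as does whether the 3-cyanopropyl chain would have the same lack of effect on a compound with a stronger starting value.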